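Replacing the 3-chlorophenyl group of compound 3

This account rests on a few compounds, and the source may have more. Where it says the series, first, only, none or still open, it means among the compounds named here.

Of the compounds shown here, three sharing one core have been tested in a functional assay on ECa-109 cells (Homo sapiens) for antiproliferative activity, read by MTT assay, with a stated time of 72 h; a higher number here means a weaker inhibitor, a lower number a stronger inhibitor. Compound 1 `CCCSc1nc(N/N=C/c2ccc(C)cc2)c2nnn(Cc3ccccc3)c2n1` gives > 64000 nM, which is a limit of the assay and not a number. Compound 3 `CCCSc1nc(N/N=C/c2cccc(Cl)c2)c2nnn(Cc3ccccc3)c2n1` gives > 64000 nM, again only a limit. Compound 3 therefore sits with compound 1 at the limit of > 64000 nM in this assay, at which 2 of the 3 values shown sit. Compound 2 `C#CCSc1nc(N/N=C/c2ccc(N(C)C)cc2)c2nnn(Cc3ccccc3)c2n1` gives an actual number, 31300 nM.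

The next compound, compound 4 `CCCSc1nc(N/N=C/c2ccc(N(C)C)cc2)c2nnn(Cc3ccccc3)c2n1`, is compound 3 with one change: 4-(dimethylamino)phenyl in place of 3-chlorophenyl on a carbon with a double bond to nitrogen, (4-(dimethylamino)phenyl in place of 3-chlorophenyl on a carbon with a double bond to nitrogen).

For the measured compounds named here, the only measured step at this place is a step that the two limits leave unreadable from compound 1 to compound 3, so it offers no size to carry over. The remaining guide is compound 2, which carries the same 4-(dimethylamino)phenyl and gives 31300 nM in this assay. A single compound is thin support, so the expectation is a cautious one. The expected step, an at least 1.3-fold lower number from compound 3 to compound 4 (0.12 log units; that floor lies within the scatter), is modest and points toward stronger inhibition, though the result may also stay at the limit. For compound 4 the estimate is 48000 nM, with an expected range from 22000 nM to 100000 nM.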

Compound 4, half-maximal inhibitory concentration: 20000 nM
The estimate for compound 4 lay 2.4-fold (0.38 log units) above the measured number; the measured number lies below the stated range.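

In this assay, this position can clearly change the read-out: 4-(dimethylamino)phenyl in place of 3-chlorophenyl gives an at least 3.2-fold lower number from compound 3 to compound 4 (0.50 log units; beyond the scatter), and dimethylamino in place of methyl on an aromatic carbon gives an at least 3.2-fold lower number from compound 1 to compound 4 (0.50 log units; beyond the scatter). Both steps lie beyond the scatter, so they supply a lower bound on size at a place where the earlier step between two limits could not be read. The group on the chain bound to sulfur matters less in this pair, as ethyl in place of ethynyl gives a 1.6-fold lower number from compound 2 to compound 4 (0.19 log units; within the scatter), and the two compounds carrying 4-(dimethylamino)phenyl give actual numbers, whereas the other two remain at the limit: the limit of > 64000 nM in this assay, at which 2 of the 4 values shown sit.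

The compounds shown leave open whether the dimethylamino group itself is needed, or whether a primary amine, a morpholine or a methoxy group in its place would read the same. They also leave open how a longer chain on the sulfur would read when paired with 4-(dimethylamino)phenyl.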